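Replacing 1-benzothiophen-2-yl with 5-methylthiophen-2-yl

The compounds below may be only part of what the source reports. "The series", "measured", "known", "first", "only" and "open" are said of these compounds alone.

In a functional assay on MGC-803 cells (Homo sapiens) for antiproliferative activity, read by MTT assay, with a stated time of 72 h (on this read-out lower numbers stand for stronger inhibition and higher numbers for weaker inhibition), compound 1 `Cc1ccc(-c2nc(CNc3ccc(C(=O)NO)cc3)n(-c3ccccc3)n2)cc1` reads > 20000 nM, which is a limit of the assay and not a number. Going by the values given here, compound 2 `O=C(NO)c1ccc(NCc2nc(-c3cc4ccccc4s3)nn2-c2ccccc2)cc1` gives 6110 nM, the only actual number so far. Compound 3 `Cc1ccc(-c2nc(CNc3ccc(C(=O)NO)cc3)n(-c3ccccc3)n2)s1` carries 5-methylthiophen-2-yl in place of 1-benzothiophen-2-yl on an aromatic carbon. Among the compounds with values here, the one measured step that bears on this is an at least 3.2-fold lower number from compound 1 to compound 2 (0.51 log units; beyond the scatter), where 1-benzothiophen-2-yl replaced 4-methylphenyl. The new change removes the benzothiophene again, so weaker inhibition is expected, with an estimated 2.3-fold higher number from compound 2 to compound 3 (0.36 log units; beyond the scatter). For compound 3 the expected value is 14000 nM, within an estimated range of 6000 nM to 32000 nM.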

Compound 3, half-maximal inhibitory concentration: 8450 nM
Beside the measured number, compound 3's estimate is 1.7-fold (0.22 log units) above it; measured number inside the range.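

Placed on this aromatic carbon, 5-methylthiophen-2-yl and 1-benzothiophen-2-yl cannot be told apart, with a 1.4-fold higher number from compound 2 to compound 3 (0.14 log units; within the scatter), so the six-membered aromatic ring of carbon is not required for the reading of compound 2. The five-membered aromatic ring with its sulfur, without that fused ring, also reads clearly lower than 4-methylphenyl, with an at least 2.3-fold lower number from compound 1 to compound 3 (0.37 log units; beyond the scatter). The full size of that step cannot be read, as the value of compound 1 is a limit and not a number: the limit of > 20000 nM in this assay, at which 1 of the 3 values shown sits.

It remains open whether the methyl group on the thiophene matters, since unsubstituted thiophen-2-yl is not among the compounds shown. Also open, as far as these compounds go, is how furan-2-yl or an amine-bearing thiophene would read at this position.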